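The source may hold more compounds than are shown below. What is called first, only, known or untested is meant among the compounds shown, and "the series" means these compounds.

Of the compounds shown here, two have so far been measured in a toxicity assay on HepG2 2.2.15 cells (Homo sapiens) for cytotoxicity, read by CCK-8 assay, with a stated time of 8 days; a lower number here means that less compound is tolerated, a higher number that more compound is tolerated. Compound 1 `CC(C)Cc1nn(-c2cccc(F)c2)cc1C(=O)NCc1ccccc1` gives 85900 nM in this assay. Compound 2 `CCOC(=O)c1cn(-c2cccc([N+](=O)[O-])c2)nc1CC(C)C`, which carries a different set of groups around the shared core, gives 59300 nM in this assay. These two numbers sit within the usual scatter of each other, so on what has been measured compound 1 cannot be set apart from compound 2 as either more or less tolerated; both are tolerated only at rather high concentrations, which is the usual hope for a cytotoxicity read-out.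

Compound 3 `CC(C)Cc1nn(-c2cccc(F)c2)cc1C(=O)Nc1ccc(F)cc1` has not yet been measured. It differs from compound 1 in one place: 4-fluorophenyl in place of benzyl on an amide-type nitrogen. Among the measured compounds shown here, no measured pair shows what this change does in this assay, so the expectation rests on the nearby numbers alone. Both numbers seen so far lie high and close together, and a step no larger than the scatter, in either direction, is what is expected here. The expected step is a 1.2-fold lower number from compound 1 to compound 3 (0.09 log units; within the scatter). Compound 3 is therefore expected to give about 70000 nM in this assay, with a range from 30000 nM to 160000 nM.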

Compound 3, half-maximal cytotoxic concentration: 36200 nM
The estimate for compound 3 lay 1.9-fold (0.29 log units) above the measured number, within the range that was stated.
By their numbers in this assay, from the lowest: compounds 3, 2 and 1 (each within the scatter of the next, the first and the last beyond it).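

In this assay, among the compounds shown here, putting 4-fluorophenyl in place of benzyl on the amide-type nitrogen gives a 2.4-fold lower number from compound 1 to compound 3 (0.38 log units; beyond the scatter), the first evidence that this position can change how much compound the cells tolerate, since the rest of the structure stays the same. The shift is modest, but it appears even though the two groups match in heavy-atom count, each has one six-membered aromatic ring of carbon only, and neither adds hydrogen-bond donors, acceptors or a net charge. Nothing measured here explains the step.

This single change alters two things at once: the carbon link between the nitrogen and the ring is gone, and a fluorine is present, so plain phenyl and 4-fluorobenzyl on this nitrogen would be the comparisons needed to tell these two apart. From the compounds shown here alone, it also remains open how far this position can move the number with a quite different group there, such as a short alkyl chain, an amine or a carboxylic acid.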